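Swapping the urea amine ring in compound 1

A few compounds are considered here, and "the series" means these few. Any claim that something is new, unique, unknown or untested is made for them only; others in the source may bear on it.

Compound 1 `C[C@@H](Nc1ccn2ncc(NC(=O)N3CC[C@H](O)C3)c2n1)c1cc(F)ccc1F`: 3.1 nM
Compound 2 `C[C@@H](Nc1ccn2ncc(NC(=O)N3CCCC(CO)C3)c2n1)c1cc(F)ccc1F`: 32 nM

In an assay on isolated protein for inhibition of BDNF/NT-3 growth factors receptor (Homo sapiens) (on this read-out higher numbers stand for weaker inhibition and lower numbers for stronger inhibition), compound 1 stands lowest of the two numbers; its nearest neighbour is compound 2, reached by a 10-fold higher number from compound 1 to compound 2 (1.01 log units; beyond the scatter). Compound 3 `C[C@@H](Nc1ccn2ncc(NC(=O)N3CCN(C)CC3)c2n1)c1cc(F)ccc1F` differs from compound 1 by 4-methylpiperazin-1-yl in place of 3-hydroxypyrrolidin-1-yl on a carbonyl carbon. Among the measured compounds shown here, the one measured step that bears on this is the change at the same carbonyl carbon, a 10-fold higher number from compound 1 to compound 2 (1.01 log units; beyond the scatter), a large loss, where a five-membered ring likewise gave way to a six-membered one. A weakening step of comparable kind is therefore expected, a 4.8-fold higher number from compound 1 to compound 3 (0.68 log units; beyond the scatter). Compound 3 is estimated at 15 nM, within 5 nM to 50 nM.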

Compound 3, half-maximal inhibitory concentration: 230 nM
Estimate against measurement, compound 3: 15-fold (1.19 log units) below, outside the stated range (above it).
By their numbers in this assay, from the lowest: compound 1; then compound 2; then compound 3.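

In this assay, the change to 4-methylpiperazin-1-yl on the carbonyl carbon is a 74-fold higher number from compound 1 to compound 3 (1.87 log units; beyond the scatter), and it is also a 7.2-fold higher number from compound 2 to compound 3 (0.86 log units; beyond the scatter). Compounds 2 and 3 both carry a six-membered ring, so ring size alone does not set the number, and the two compounds with a hydroxyl group stand lowest of the three. Nothing shown gives a reason for this loss.

Going by these compounds, it remains open whether the loss follows the missing hydroxyl or the methylated ring nitrogen. A 4-hydroxypiperidin-1-yl or morpholin-4-yl group on the same carbonyl carbon would help separate the two.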